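Selenium Sugar Uracil Nucleosides Tested for Cytotoxicity

The compounds below may be only part of what the source reports. "The series", "measured", "known", "first", "only" and "open" are said of these compounds alone.

Three selenium-containing nucleosides were examined in a functional assay on HCT-116 cells (Homo sapiens) for cytotoxicity, read by sulforhodamine B assay; on this read-out higher numbers stand for weaker inhibition and lower numbers for stronger inhibition. Compound 1 has the structure `[N-]=[N+]=N[C@@H]1C(n2ccc(=O)[nH]c2=O)[Se][C@H](CO)[C@H]1O`. In this assay compound 1 gives only a limit, > 100000 nM. Compound 2, `Cc1cn(C2[Se][C@H](CO)[C@@H](O)[C@@H]2N=[N+]=[N-])c(=O)[nH]c1=O`, differs from compound 1 by methyl in place of hydrogen on an aromatic carbon. In this assay compound 2 likewise reaches only a limit, > 100000 nM. Compound 3, `O=c1ccn(C2[Se][C@H](CO)[C@@H](O)[C@@H]2O)c(=O)[nH]1`, differs from compound 1 by hydroxy in place of azido on a saturated ring carbon. In this assay compound 3 also gives only a limit, > 100000 nM. The step that the two limits leave unreadable from compound 1 to compound 2 and the step that the two limits leave unreadable from compound 1 to compound 3 cannot be sized because of the limit of > 100000 nM in this assay, at which 3 of the 3 values shown sit. Compound 4, `Cc1cn(C2[Se][C@H](CO)[C@@H](O)[C@@H]2O)c(=O)[nH]c1=O`, has not yet been tested; it differs from compound 3 by methyl in place of hydrogen on an aromatic carbon, the same kind of change as that from compound 1 to compound 2, though here the place is described as meta to a group of 9 heavy atoms rather than to a large group. The step that the limit leaves unreadable from compound 3 to compound 4 is expected to be small, resting on compound 3 giving > 100000 nM and on (the limit of > 100000 nM in this assay, at which 3 of the 3 values shown sit). Compound 4 is therefore estimated at 150000 nM, most likely again only a limit.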

Compound 4, half-maximal inhibitory concentration: > 100000 nM
Compound 4 gave a limit, no number; the forecaster's own chance of this, stated with the estimate: 90%; the middle value does not contradict the limit.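

In this assay compound 4 gives only a limit, > 100000 nM. Neither the step from compound 3 to compound 4 nor the step from compound 2 to compound 4 can be read, and the reason is: the limit of > 100000 nM in this assay, at which 4 of the 4 values shown sit. The compounds shown leave open whether any change among them shifts the read-out at all; none of the four carries a number.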